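Piperazine in Place of an Open-Chain Diamine

A few compounds are considered here, and "the series" means these few. Any claim that something is new, unique, unknown or untested is made for them only; others in the source may bear on it.

Measured compounds:
compound 1, `NCCCNc1c(C(=O)NCc2ccc(F)cc2)nc(Br)c2cccnc12`, > 20000 nM;
compound 2, `N[C@H]1CC[C@H](Nc2c(C(=O)NCc3ccc(F)cc3)nc(N3CCCCC3)c3cccnc23)CC1`, 8000 nM.

Of the compounds shown here, two sharing one core have been tested in a functional assay on HCT-116 cells (Homo sapiens) for cytotoxicity, read by MTT assay, with a stated time of 72 h; on this read-out lower numbers stand for stronger inhibition and higher numbers for weaker inhibition. For compound 1 the result is only a limit, not a number, so in this assay compound 1 gives > 20000 nM. Compound 2 carries a different set of groups on the shared core and in this assay compound 2 gives 8000 nM. Of the two values shown, one sits at the limit of the assay, as the limit of > 20000 nM in this assay, at which 1 of the 2 values shown sits, records, so compound 1 stands at the weak end of what the assay can report.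

Compound 3, `O=C(NCc1ccc(F)cc1)c1nc(Br)c2cccnc2c1N1CCNCC1`, differs from compound 1 in one place: piperazin-1-yl in place of (3-aminopropyl)amino on an aromatic carbon. The open chain is replaced by a ring while the rest of compound 1 is kept. Because compound 1 gives > 20000 nM, there is no measured number to anchor a step, and no change beyond the usual scatter is expected. The step from compound 1 to compound 3 is estimated as an at least 1.3-fold lower number from compound 1 to compound 3 (0.12 log units; that floor lies within the scatter). In this assay compound 3 is expected to give about 15000 nM, with a likely range from 4000 nM to 40000 nM.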

Compound 3, half-maximal inhibitory concentration: > 10000 nM
Compound 3: only a limit was reported; the forecaster's own chance of this, stated with the estimate: 50%; the middle value is on the limit's open side.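

Going by these compounds alone, compound 1 and compound 3 both have only limits in this assay, not numbers, and no step between them can be read. The compounds shown leave open how much piperazin-1-yl in place of (3-aminopropyl)amino changes the cytotoxicity, and whether either compound has a measurable value in this test.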